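This account rests on a few compounds, and the source may have more. Where it says the series, first, only, none or still open, it means among the compounds named here.

The measured compounds and their values in a functional assay on U-251 cells (Homo sapiens) for cytotoxicity, read by sulforhodamine B assay, with a stated time of 48 h; on this read-out higher numbers stand for weaker inhibition of growth and lower numbers for stronger inhibition of growth:

compound 1, `ClCc1ccccc1Cn1cnc2c(Cl)nc(Cl)nc21`, 310 nM;
compound 2, `ClCc1cccc(Cn2cnc3c(Cl)nc(Cl)nc32)c1`, 1690 nM;
compound 3, `Nc1nc(Cl)c2ncn(Cc3ccccc3CCl)c2n1`, 3470 nM.

Compound 1 and compound 2 are built from the same atoms joined differently; how the two cores differ is not broken down here. Compound 3 arises from compound 1 by one change, (amino in place of chloro on an aromatic carbon), and in this assay that step made an 11-fold higher number from compound 1 to compound 3 (1.05 log units; beyond the scatter). Compound 2 gives the second highest of the three numbers; compound 3 gives a number higher still, while compound 1 gives the lowest of the three.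

Compound 4, `Nc1nc(Cl)c2ncn(Cc3cccc(CCl)c3)c2n1`, has not yet been measured in this assay. It stands to compound 2 exactly as compound 3 stands to compound 1: the change is amino in place of chloro on an aromatic carbon, the same change at the same place, and this is the second of two such pairs among the compounds shown.

In this assay compound 4 is therefore expected to show an 8.9-fold higher number from compound 2 to compound 4 (0.95 log units; beyond the scatter), an expectation that rests on compound 1 and compound 3, because an 11-fold higher number from compound 1 to compound 3 (1.05 log units; beyond the scatter) was seen when this change was made there. Compound 4 is estimated at 15000 nM, with the expected range running from 5000 nM to 50000 nM.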

Compound 4, concentration for 50% growth inhibition: 1820 nM
The estimate for compound 4 lay 8.2-fold (0.92 log units) above the measured number; measured number outside the range, below it.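

In this assay, the step of a 1.1-fold higher number from compound 2 to compound 4 (0.03 log units; within the scatter) shows no real change, so amino in place of chloro on an aromatic carbon did not repeat on this core what it had done on the core of compound 1. Set side by side, the two steps part by more than the scatter of such steps, which means that in these two pairs the size of the change depends on the core that carries it: the same change on two cores in this assay, an 11-fold higher number (1.05 log units; beyond the scatter) from compound 1 to compound 3 and a 1.1-fold higher number (0.03 log units; within the scatter) from compound 2 to compound 4, 10-fold (1.02 log units) apart, beyond the scatter of two such steps. This shows that the step read on one core could not be carried over to the other here, but it does not show why the two cores part, and two pairs set no rule for the wider series.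

The compounds shown leave open whether the cores would also part for another group on the same aromatic carbon between two ring nitrogen atoms, such as a methylamino or a methoxy group. They also leave open whether either core would respond in the same way if the chloro group that stays on the ring were replaced by an amine.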